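Swapping oxan-4-yl for isopropyl on an aromatic nitrogen

The source may hold more compounds than are shown below. What is called first, only, known or untested is meant among the compounds shown, and "the series" means these compounds.

Values measured so far in a physicochemical assay for solubility, in phosphate buffer, at pH 7.4 (on this read-out higher numbers stand for higher solubility and lower numbers for lower solubility), are these
compound 1 `CC(C)n1cc(-c2ccnc3[nH]c(C4CCN(CC(=O)N(C)C)CC4)cc23)cnc1=O` gives 910000 nM
compound 2 `CN(C)C(=O)CN1CCC(c2cc3c(-c4ccc(=O)n(C5CCOCC5)c4)ccnc3[nH]2)CC1` gives 840000 nM

Compound 2 stands level with compound 1: the two numbers lie within the usual scatter of repeated measurements, so neither can be ranked above the other. Compound 3 `CC(C)n1cc(-c2ccnc3[nH]c(C4CCN(CC(=O)N(C)C)CC4)cc23)ccc1=O` has not yet been measured. It is compound 2 with isopropyl in place of oxan-4-yl on an aromatic nitrogen, and the full count of what changes reads isopropyl in place of oxan-4-yl on an aromatic nitrogen with the rest of the molecule untouched. Among the compounds with values here, no measured pair here differs in one place only, so there is no direct guide to this kind of change. Within the data shown here, the only evidence is the two numbers themselves: compound 1 at 910000 nM and compound 2 at 840000 nM sit close together in this assay and offer no reason to expect a large move. No shift beyond the scatter is expected in either direction. The expected step is a 1.1-fold lower number from compound 2 to compound 3 (0.02 log units; within the scatter) and nothing larger. Compound 3 is estimated at 800000 nM with an expected range of 400000 nM to 1200000 nM on repeat measurement.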

Compound 3, solubility: 110000 nM
The estimate for compound 3 lay 7.3-fold (0.86 log units) above the measured number; measured number outside the range, below it.
By their numbers in this assay, from the lowest: compound 3; then compounds 2 and 1 (each within the scatter of the next).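

In this assay, the group on this aromatic nitrogen proves able to move the number a long way: isopropyl in place of oxan-4-yl gives a 7.6-fold lower number from compound 2 to compound 3 (0.88 log units; beyond the scatter). Isopropyl alone does not go with a low number, however, since compound 1 carries it too; replacing the six-membered aromatic ring with 2 hetero atoms in compound 1 by the ring with 1 hetero atom gives an 8.3-fold lower number from compound 1 to compound 3 (0.92 log units; beyond the scatter), so the effect of the isopropyl group may depend on the ring that carries it. Nothing available here explains why either step is so large.

It remains open whether the oxan-4-yl group makes any difference on the ring with 2 hetero atoms, as the compounds shown pair that group only with the ring with 1 hetero atom. Going by these compounds, it is also open where other groups on the same nitrogen would fall between compound 2 and compound 3, for example a methyl group, a cyclopropyl ring or a piperidine ring, which would carry an amine nitrogen in place of the oxygen of oxan-4-yl.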